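The source may hold more compounds than are shown below. What is called first, only, known or untested is meant among the compounds shown, and "the series" means these compounds.

Three compounds that share a core were measured in a functional assay on thoracic aorta (Rattus norvegicus, strain Wistar), with a stated time of 15 min; on this read-out lower numbers stand for an effect already at smaller amounts and higher numbers for an effect only at larger amounts of compound. Compound 1 `COc1ccc(F)cc1C(C)NC(=O)N(C)S(=O)(=O)c1ccc(Cl)cc1` gives 12600 nM in this assay. Compound 2 `CCOc1ccc(F)cc1C(C)NC(=O)N(C)S(=O)(=O)c1ccc(Cl)cc1` gives 24500 nM. Compound 3 `CCOc1ccc(Br)cc1C(C)NC(=O)N(C)S(=O)(=O)c1ccc(C)cc1` gives 28600 nM; the numbers for compound 3 and compound 2 lie within the scatter of each other, while the number for compound 1 is lower than that of compound 3 by a gap that goes beyond the scatter.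

Compound 2 and compound 1 differ in one place only, (hydrogen in place of methyl on a saturated chain carbon bound to an oxygen on an aromatic ring), and this brought a 1.9-fold lower number from compound 2 to compound 1 (0.29 log units; within the scatter). Compound 4 `COc1ccc(Br)cc1C(C)NC(=O)N(C)S(=O)(=O)c1ccc(C)cc1` has not yet been measured. It stands to compound 3 as compound 1 stands to compound 2, carrying the same change, (hydrogen in place of methyl on a saturated chain carbon bound to an oxygen on an aromatic ring). The difference between the core of compound 2 and the core of compound 3 is not broken down here.

Because the earlier step of a 1.9-fold lower number from compound 2 to compound 1 (0.29 log units; within the scatter) lay within the scatter, a step of similar small size is expected in this assay, namely a 1.9-fold lower number from compound 3 to compound 4 (0.28 log units; within the scatter). Compound 4 is therefore estimated to give 15000 nM in this assay, most likely between 7000 nM and 35000 nM.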

Compound 4, half-maximal effective concentration: 19100 nM
Compound 4: middle estimate off by 1.3-fold (0.10 log units), on the low side; low and high end bracket the measured number.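

On the core of compound 3, going from ethoxy to methoxy brought a 1.5-fold lower number from compound 3 to compound 4 (0.18 log units; within the scatter) in this assay. Set beside the earlier case on the core of compound 2, the two steps agree in size, so in this pair of cores the change carries over with no visible difference: the same change on two cores in this assay, a 1.9-fold lower number (0.29 log units; within the scatter) from compound 2 to compound 1 and a 1.5-fold lower number (0.18 log units; within the scatter) from compound 3 to compound 4, 1.3-fold (0.11 log units) apart, within the scatter of two such steps

Each step on its own lies within the scatter, which leaves open whether the change has any real effect on the read-out, and two cores cannot speak for the whole series.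

The compounds shown carry only ethoxy or methoxy at this place, so it remains open how a longer chain such as propoxy, a branched chain such as isopropoxy, or a simple hydroxyl group would behave. Also open is how the separate differences between the core of compound 2 and the core of compound 3 each contribute, since no compound shown changes them one at a time.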